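Swapping the aryl group on the amine of a diterpenoid lactone

The source may hold more compounds than are shown below. What is called first, only, known or untested is meant among the compounds shown, and "the series" means these compounds.

Three compounds of a shared core, measured in a functional assay on MCF7 cells (Homo sapiens) for cytotoxicity, read by sulforhodamine B assay (on this read-out lower numbers stand for stronger inhibition and higher numbers for weaker inhibition), set the scene. Compound 1 `C=C1[C@@H](OC(C)=O)C[C@@H]2[C@](C)(CO[Si](C)(C)C(C)(C)C)[C@H](OC(C)=O)CC[C@@]2(C)[C@@H]1C[C@@H](Nc1ccccc1F)C1=CCOC1=O` gives 2930 nM, and compound 3 `C=C1[C@@H](OC(C)=O)C[C@@H]2[C@](C)(CO[Si](C)(C)C(C)(C)C)[C@H](OC(C)=O)CC[C@@]2(C)[C@@H]1C[C@@H](Nc1cccc(F)c1)C1=CCOC1=O` gives 3820 nM; the two differ only in where the fluorine sits, and a 1.3-fold higher number from compound 1 to compound 3 (0.12 log units; within the scatter). Compound 2 `C=C1[C@@H](OC(C)=O)C[C@@H]2[C@](C)(COC=O)[C@H](OC(C)=O)CC[C@@]2(C)[C@@H]1C[C@@H](Nc1ccccc1C(=O)O)C1=CCOC1=O` gives 30800 nM, the highest number of the three and thus the weakest inhibition, separated from both compound 1 and compound 3 by more than the usual scatter. Compound 2 differs from them in two places at once, so neither difference can be weighed on its own.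

Compound 4 `C=C1[C@@H](OC(C)=O)C[C@@H]2[C@](C)(COC=O)[C@H](OC(C)=O)CC[C@@]2(C)[C@@H]1C[C@@H](Nc1ccc(F)cc1)C1=CCOC1=O` is not yet measured. Relative to compound 2 the change is 4-fluorophenyl in place of 2-carboxyphenyl on an amine nitrogen. The chain ester of compound 2 is kept, so only the aryl group moves. Among the compounds with values here, no measured pair isolates the carboxyphenyl-to-fluorophenyl exchange; the one measured step, from compound 1 to compound 3, concerns only the fluorine position and was within the scatter. The lower numbers of compound 1 and compound 3 suggest a fluorophenyl partner goes with stronger inhibition, yet the chain group differs too. The expected step of a 3.9-fold lower number from compound 2 to compound 4 (0.59 log units; beyond the scatter) is therefore toward a lower number, with wide uncertainty. Compound 4 is estimated at 8000 nM, between 2500 nM and 25000 nM.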

Compound 4, half-maximal inhibitory concentration: 12400 nM
Compound 4: the middle estimate sits 1.6-fold (0.19 log units) below what was measured, and the stated range covers the measured number.
By their numbers in this assay, from the lowest: compounds 1 and 3 (each within the scatter of the next); then compound 4; then compound 2.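

Within the data shown here, with the chain ester held fixed, compound 2 and compound 4 isolate the group on the amine nitrogen for the first time, and in this assay this exchange alone gives a 2.5-fold lower number from compound 2 to compound 4 (0.40 log units; beyond the scatter). Among these compounds, the aryl group therefore counts on its own at this position, beyond the scatter, whereas the only earlier single-place step moved a fluorine and stayed within it. Compound 4 differs from compound 1 and compound 3 in two places, so these pairs cannot be read as steps and the part played by the chain group stays unresolved, and no measurement here accounts for the change in the aryl group.

The exchange also removes the carboxylic acid, adds a fluorine and changes the substitution position together, so the step cannot be assigned to any one of these alone. On the same shared core with the chain ester, a plain phenyl group or a methyl ester of the 2-carboxyphenyl group would help separate these parts, while a silyl ether chain paired with the 2-carboxyphenyl group would test the chain group separately.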